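The source may report more compounds than this note shows. Statements on the series, on what has been measured and on what is new or still open speak of the compounds shown alone.

Compound 1 `Nc1scc(CN2CCN(c3ccccc3C(F)(F)F)CC2)c1C(=O)c1ccc(Cl)cc1` gives -39% in a functional assay on CHO cells with adenosine receptor A1 (Homo sapiens) as the target, read by cAMP accumulation and immunoassay, with a stated time of 6 min, tested at 1 uM (a lower number here means a stronger effect, a higher number a weaker effect of the compound at the concentration tested), the lowest of the three numbers measured. Compound 2 `Nc1scc(CN2CCN(C3CCCCCC3)CC2)c1C(=O)c1ccc(Cl)cc1` gives 3.7%, and compound 3 `Nc1scc(CN2CCN(c3cccc4ccccc34)CC2)c1C(=O)c1ccc(Cl)cc1` gives 2.9%; the step of a number 0.8 percentage points lower from compound 2 to compound 3 (within the scatter) lies within the scatter. Compound 4 `Nc1scc(CN2CCN(c3c(F)cc(F)cc3F)CC2)c1C(=O)c1ccc(Cl)cc1` differs from compound 1 by 2,4,6-trifluorophenyl in place of 2-(trifluoromethyl)phenyl on an amine nitrogen in a ring. Among the compounds with values here, two measured steps bear on this change, both starting from compound 1 and exchanging the same group: a number 42.7 percentage points higher from compound 1 to compound 2 (beyond the scatter) and a number 41.9 percentage points higher from compound 1 to compound 3 (beyond the scatter), each large and upward. Neither of them kept a phenyl carrying fluorine, so what such a phenyl does is not shown directly, but both steps point upward. A moderate upward step is therefore expected, a number 24 percentage points higher from compound 1 to compound 4 (beyond the scatter). Compound 4 is estimated at -15%, within a range from -45% to 10%.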

Compound 4, a percentage reported as activity, at one concentration (the size of the read-out at that concentration, not a potency): -56%
Beside the measured number, compound 4's estimate is 41 percentage points above it; measured number below the stated range.
By their numbers in this assay, from the lowest: compound 4; then compound 1; then compounds 3 and 2 (each within the scatter of the next).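

Within the data shown here, the change from 2-(trifluoromethyl)phenyl to 2,4,6-trifluorophenyl on this ring nitrogen moves the read-out of this assay downward (a number 17 percentage points lower from compound 1 to compound 4 (beyond the scatter)), so a different phenyl here can strengthen the effect, which the earlier steps away from phenyl did not show. The gaps to the two non-fluorinated groups are far larger (a number 58.9 percentage points lower from compound 3 to compound 4 (beyond the scatter) and a number 59.7 percentage points lower from compound 2 to compound 4 (beyond the scatter)), placing compound 4 well apart from both. No available data explain this difference. As far as these compounds go, whether a phenyl carrying chlorine or methoxy, or a pyridine ring, would go lower still at this nitrogen remains open.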